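The compounds below may be only part of what the source reports. "The series", "measured", "known", "first", "only" and "open" are said of these compounds alone.

Measured compounds:
compound 1 `Cc1cn([C@H]2C[C@H](SSc3ccccc3[N+](=O)[O-])[C@@H](CO)O2)c(=O)[nH]c1=O` — in a physicochemical assay for metabolic stability, in the presence of a further agent that is not named here (on this read-out higher numbers stand for a longer-lived compound and lower numbers for a shorter-lived compound), compound 1 gives < 0.167 h, a limit of the assay.
compound 2 `C=CCSS[C@H]1C[C@H](n2cc(C)c(=O)[nH]c2=O)O[C@@H]1CO` — in this assay compound 2 gives < 8 h, likewise a limit of the assay.

Compound 2 therefore stands only at a limit in this assay, one of two limits shown: the limit of < 0.167 h in this assay, at which 1 of the 2 values shown sits, and (the limit of < 8 h in this assay, at which 1 of the 2 values shown sits). The step that the two limits leave unreadable from compound 1 to compound 2 is unreadable between them. Compound 3 `CCCCSS[C@H]1C[C@H](n2cc(C)c(=O)[nH]c2=O)O[C@@H]1CO` differs from compound 2 by propyl in place of vinyl on a saturated chain carbon bound to a sulfur. For the measured compounds named here, no measured step bears on this change, and the limits give no size for any step. For compound 3 the value in this assay is estimated at 3 h, expected between 0.5 h and 8 h, the expected step being a step that the limit leaves unreadable from compound 2 to compound 3.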

Compound 3, half-life: < 8 h
Compound 3: only a limit was reported (the forecaster's own chance of this, stated with the estimate: 40%); the middle value does not contradict the limit.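

In this assay compound 3 gives < 8 h, a limit of the assay. For the compounds shown here, with only limits for compound 1, compound 2 and compound 3, no step among them can be read. From the compounds shown here alone, whether allyl, butyl or 2-nitrophenyl on a sulfur gives the longer half-life stays open.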